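Swapping Dimethylamino for Fluoro on the Aromatic Ring

A few compounds are considered here, and "the series" means these few. Any claim that something is new, unique, unknown or untested is made for them only; others in the source may bear on it.

Compound 1 `CC1=CC[C@H](C(C)(C)NC(=S)N/N=C/c2ccccc2)CC1` and compound 2 `CC1=CC[C@H](C(C)(C)NC(=S)N/N=C/c2ccc(N(C)C)cc2)CC1` share one core and differ at a single aromatic carbon. In a functional assay on U-251 cells (Homo sapiens) for inhibition, read by sulforhodamine B assay, with a stated time of 48 h (a lower number here means a stronger inhibitor of growth, a higher number a weaker inhibitor of growth), compound 1 gives 71400 nM. For compound 2 this assay reports only a limit, > 100000 nM, and not a number. Going by these compounds, compound 2 therefore stands at the limit of > 100000 nM in this assay, at which 1 of the 2 values shown sits, so where it truly lies within that bound is unknown. Among the measured compounds shown here, the one measured step, an at least 1.4-fold higher number from compound 1 to compound 2 (0.14 log units; that floor lies within the scatter), is small enough that it cannot be separated from ordinary repeat variation.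

Compound 3 `CC1=CC[C@H](C(C)(C)NC(=S)N/N=C/c2ccc(F)cc2)CC1` is reached from compound 2 by a single change: fluoro in place of dimethylamino on an aromatic carbon. For the measured compounds named here, the only measured step that bears on this change is the one going the other way, an at least 1.4-fold higher number from compound 1 to compound 2 (0.14 log units; that floor lies within the scatter), and that step lay within the scatter. The dimethylamino that compound 2 carries is removed again, so the expected step in this assay for compound 3 is an at least 1.2-fold lower number from compound 2 to compound 3 (0.09 log units; that floor lies within the scatter), a move back toward the number seen for compound 1 rather than anything large. Compound 3 is accordingly estimated at 80000 nM in this assay, with a range from 40000 nM to 160000 nM.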

Compound 3, concentration for total growth inhibition: > 100000 nM
Compound 3: a limit, no number; the forecaster's own chance of this, stated with the estimate: 35%; middle value at least 1.2-fold (0.09 log units) from the limit.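

With compound 3, a second group on this aromatic carbon, para to a large group, ends in a limit and not a number, as dimethylamino did in compound 2: the limit of > 100000 nM in this assay, at which 2 of the 3 values shown sit. Fluoro in place of hydrogen at this carbon gives an at least 1.4-fold higher number from compound 1 to compound 3 (0.14 log units; that floor lies within the scatter), so the printed floor is the same one that dimethylamino gave, and neither floor is separated from ordinary repeat variation. The step between compound 2 and compound 3 cannot be read, so the exchange of dimethylamino for fluoro has no measured size in this assay, and the two compounds cannot be placed in any order.

How far compound 2 and compound 3 truly lie from compound 1 remains open, and a real loss of growth inhibition on replacing hydrogen at this carbon is neither shown nor ruled out. Also open, going by these compounds, is whether a hydroxyl, a methoxy group, a carboxylic acid or a longer chain at this aromatic carbon would give a readable number in this assay, and whether any such number would lie beyond the scatter from compound 1.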